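This account rests on a few compounds, and the source may have more. Where it says the series, first, only, none or still open, it means among the compounds named here.

Three compounds of one shared core carry an amide chain on the same ring, and they differ only in what sits at the end of that chain. Compound 1 `Cn1c(-c2ccc(NC(=O)CCl)cc2)nc(-c2ccccc2)c1-c1ccccc1` ends in a chloro group and gives 4.3% in a functional assay on MCF7 cells (Homo sapiens) for cytotoxicity, read by MTT assay, with a stated time of 24 h, tested at 1.6 ug/mL; a lower number here means a weaker effect, a higher number a stronger effect of the compound at the concentration tested. Compound 2 `Cn1c(-c2ccc(NC(=O)CSc3nc4ccccc4o3)cc2)nc(-c2ccccc2)c1-c1ccccc1` ends in a (1,3-benzoxazol-2-yl)sulfanyl group; in this assay compound 2 gives 27.4%, the second highest of the three numbers, a number 23.1 percentage points higher from compound 1 to compound 2 (beyond the scatter). Compound 3 `Cn1cnnc1SCC(=O)Nc1ccc(-c2nc(-c3ccccc3)c(-c3ccccc3)n2C)cc1` ends in a (4-methyl-4H-1,2,4-triazol-3-yl)sulfanyl group and gives 42.8% in this assay, with a number 38.5 percentage points higher from compound 1 to compound 3 (beyond the scatter) and a number 15.4 percentage points higher from compound 2 to compound 3 (beyond the scatter).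

Compound 4 `Cc1nnc(SCC(=O)Nc2ccc(-c3nc(-c4ccccc4)c(-c4ccccc4)n3C)cc2)s1` is built like compound 2 except that (5-methyl-1,3,4-thiadiazol-2-yl in place of 1,3-benzoxazol-2-yl on a sulfur). For the measured compounds named here, the step that bears on it most is the one from compound 2 to compound 3, where one ring on the sulfur was swapped for a smaller one and the read-out rose modestly. A move of similar direction, though of uncertain size, is expected here, so the step from compound 2 to compound 4 is estimated as a number 9.6 percentage points higher from compound 2 to compound 4 (within the scatter). Compound 4 is therefore expected to give about 37% in this assay, within a range from 20% to 55%.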

Compound 4, a percentage reported as activity, at one concentration (the size of the read-out at that concentration, not a potency): 37.5%
Compound 4: middle estimate off by 0.5 percentage points, on the low side; measured number inside the range.
By their numbers in this assay, from the lowest: compound 1; then compound 2; then compounds 4 and 3 (each within the scatter of the next).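

In this assay, replacing the two-ring 1,3-benzoxazol-2-yl on the sulfur with the single-ring 5-methyl-1,3,4-thiadiazol-2-yl gives a number 10.1 percentage points higher from compound 2 to compound 4 (beyond the scatter) and thus a second single-ring group that stands above the two-ring one. The two single-ring groups cannot be told apart, with a number 5.3 percentage points lower from compound 3 to compound 4 (within the scatter) in this comparison, so the exact identity of the single ring matters little among the compounds shown. The thiadiazole also extends the gain over the chloro group, with a number 33.2 percentage points higher from compound 1 to compound 4 (beyond the scatter) for the third sulfur-linked ring shown, and no compound here goes against that pattern. Nothing measured here explains these differences. On these data alone, it remains open whether a plain phenyl ring on the sulfur would match these single-ring groups. Also open, as far as these compounds go, is how an amine such as piperidine would fare on the saturated chain carbon in place of the sulfur-linked rings.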